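A few compounds are considered here, and "the series" means these few. Any claim that something is new, unique, unknown or untested is made for them only; others in the source may bear on it.

Measured compounds:
compound 1, `Cc1nc(-c2ccc(Cl)cc2)sc1C(=O)CSc1nc(-c2ccc(Cl)c(Cl)c2)c(C#N)c(=O)[nH]1`, in a functional assay on U-87MG ATCC cells for antiproliferative activity against U-87 MG (Homo sapiens), read by MTT assay, with a stated time of 48 h, tested at 10 uM (a higher number here means a weaker effect of the compound at the concentration tested, a lower number a stronger effect), compound 1 gives 97.1%
compound 2, `COc1ccc(-c2nc(SCC(=O)c3sc(-c4ccccc4)nc3C)[nH]c(=O)c2C#N)cc1OC`, compound 2 gives 69.8%
compound 3, `COc1cccc(-c2nc(SCC(=O)c3sc(-c4ccccc4)nc3C)[nH]c(=O)c2C#N)c1`, compound 3 gives 90.2%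

Compound 3 stands second highest of the three numbers. Its nearest neighbour is compound 1, whose number is higher by an amount within the scatter, so no order between the two can be claimed. Among the compounds with values here, compound 2 lies furthest away, beyond the scatter, and the one measured step, a number 20.4 percentage points higher from compound 2 to compound 3 (beyond the scatter), is a modest rise brought about by hydrogen in place of methoxy on an aromatic carbon.

Compound 4, `Cc1nc(-c2ccccc2)sc1C(=O)CSc1nc(-c2ccc(Cl)c(Cl)c2)c(C#N)c(=O)[nH]1`, has not yet been measured. It differs from compound 3 in one place: 3,4-dichlorophenyl in place of 3-methoxyphenyl on an aromatic carbon. Within the data shown here, no measured step concerns this exchange; the step from compound 2 to compound 3 changes a different group and does not bear on it. What the data do offer is compound 1, which carries the same 3,4-dichlorophenyl group and gives 97.1%, close to compound 3. Compound 4 is therefore expected to show no step beyond the scatter, a number 3.8 percentage points higher from compound 3 to compound 4 (within the scatter). The estimate for compound 4 in this assay is 94%, with a range from 80% to 100%.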

Compound 4, a percentage reported as activity, at one concentration (the size of the read-out at that concentration, not a potency): 92.5%
Compound 4: middle estimate off by 1.5 percentage points, on the high side, and the stated range covers the measured number.
By their numbers in this assay, from the lowest: compound 2; then compounds 3, 4 and 1 (each within the scatter of the next).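

In this assay, 3,4-dichlorophenyl in place of 3-methoxyphenyl, on the aromatic carbon ortho to a cyano group, gives a number 2.3 percentage points higher from compound 3 to compound 4 (within the scatter) and so does not tell these two groups apart, whereas the same group in place of 3,4-dimethoxyphenyl gives a number 22.7 percentage points higher from compound 2 to compound 4 (beyond the scatter) and leaves 3,4-dimethoxyphenyl with the stronger effect of the two. Hydrogen in place of chloro on an aromatic carbon elsewhere in the molecule gives a number 4.6 percentage points lower from compound 1 to compound 4 (within the scatter) and thus separates nothing with 3,4-dichlorophenyl held constant. Nothing in the available data accounts for the way 3,4-dimethoxyphenyl stands apart from 3,4-dichlorophenyl at this position.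

As far as these compounds go, it remains open whether a phenyl group carrying a dimethylamino group, a hydroxyl or a carboxylic acid at this position would give a lower number in this assay than compound 2 does. Since each compound is read at a single concentration, the compounds shown also leave open how their potencies compare.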